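Chloro in place of methoxy: compound 3 to compound 4

The source may report more compounds than this note shows. Statements on the series, on what has been measured and on what is new or still open speak of the compounds shown alone.

Values in a functional assay on the whole organism with Rattus norvegicus as the target; on this read-out lower numbers stand for an effect already at smaller amounts and higher numbers for an effect only at larger amounts of compound:
- compound 1 (`CSc1cc(C)nc(Cl)c1NC(=O)N(Cc1ccc(Oc2ccc(F)cc2)cc1)C1CCCCCC1`): 0.022 mg/kg
- compound 2 (`CSc1nc(C)cc(Cl)c1NC(=O)N(Cc1ccc(Oc2ccc(F)cc2)cc1)C1CCCCCC1`): < 0.1 mg/kg (a limit)
- compound 3 (`COc1nc(C)ccc1NC(=O)N(Cc1ccc(Oc2ccc(F)cc2)cc1)C1CCCCCC1`): > 0.1 mg/kg (a limit)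

From the compounds shown here alone, compound 3 gives only a limit, > 0.1 mg/kg, so its exact place stays open. Compound 4 (`Cc1ccc(NC(=O)N(Cc2ccc(Oc3ccc(F)cc3)cc2)C2CCCCCC2)c(Cl)n1`) carries chloro in place of methoxy on an aromatic carbon, next to the ring nitrogen (chloro in place of methoxy on an aromatic carbon). Within the data shown here, the one readable step is an at least 4.5-fold higher number from compound 1 to compound 3 (0.65 log units; beyond the scatter), which lies beyond the scatter. The other, a number no lower from compound 2 to compound 3 (the limit leaves the size open), leaves its size open. Neither isolates this exchange, so no step beyond the scatter is expected in this assay. The expected step is a step that the limit leaves unreadable from compound 3 to compound 4. For compound 4 the estimated value is 0.15 mg/kg, with an expected range of 0.04 mg/kg to 0.5 mg/kg.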

Compound 4, dose for half-maximal effect: > 0.1 mg/kg
Compound 4 was reported as a limit; the forecaster's own chance of this, stated with the estimate: 45%; the middle value is on the limit's open side.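

In this assay compound 4 gives only a limit, > 0.1 mg/kg. Hydrogen in place of methylsulfanyl on an aromatic carbon gives an at least 4.5-fold higher number from compound 1 to compound 4 (0.65 log units; beyond the scatter), the one single-place change in the series with a readable bound on its size. The exchange of the whole aromatic group on the amide-type nitrogen gives a number no lower from compound 2 to compound 4 (the limit leaves the size open). The step from compound 3 to compound 4 cannot be read, and chloro and methoxy next to the ring nitrogen sit at the same limit: the limit of > 0.1 mg/kg in this assay, at which 2 of the 4 values shown sit.

From the compounds shown here alone, how far compound 3 and compound 4 lie from each other remains open. So does the effect of an amine or a nitrile in place of chloro next to the ring nitrogen.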